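The source may report more compounds than this note shows. Statements on the series, on what has been measured and on what is new or still open speak of the compounds shown alone.

Compound 1 `Cc1ccc(-c2cnn3c(NCc4ccccn4)cc(C)nc23)cc1` gives < 5000 nM in a physicochemical assay for solubility, read by HPLC, using the shake flask method, measured as kinetic solubility, with a stated time of 2 h, at pH 7.4 (a lower number here means a less soluble compound, a higher number a more soluble compound), a limit.
Compound 2 `Cc1cc(NCc2ccccn2)n2ncc(-c3ccc(N(C)C)cc3)c2n1` gives < 5000 nM in this assay, also a limit.
Compound 3 `Cc1cc(NCc2ccccn2)n2ncc(-c3cccc(F)c3)c2n1` gives 5000 nM in this assay.

For the measured compounds named here, compound 3 thus carries the only number among the three results; the other two sit at the limit of < 5000 nM in this assay, at which 2 of the 3 values shown sit. The steps leading to it, a number no lower from compound 1 to compound 3 (the limit leaves the size open) and a number no lower from compound 2 to compound 3 (the limit leaves the size open), are each read only as no lower, their size left open by the limits. Compound 4 `Cc1cc(NCc2ccccn2)n2ncc(-c3ccc(F)cc3F)c2n1` differs from compound 3 by 2,4-difluorophenyl in place of 3-fluorophenyl on an aromatic carbon. Going by the values given here, none of the measured steps concerns a second fluorine, so no direction beyond the scatter is expected, and the step of a 1.3-fold lower number from compound 3 to compound 4 (0.10 log units; within the scatter) is estimated as small. Compound 4 is therefore expected near 4000 nM, within 1500 nM to 10000 nM.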

Compound 4, solubility: < 5000 nM
Compound 4: no number, only a limit (the forecaster's own chance of this, stated with the estimate: 40%); the middle value lies beyond the limit too.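

With 2,4-difluorophenyl in place of 3-fluorophenyl on this aromatic carbon, this assay gives a number no higher from compound 3 to compound 4 (the limit leaves the size open), so the second fluorine does not raise the read-out, though the result for compound 4 is a limit and not a number. The steps to compound 4 from compound 1 and from compound 2 cannot be read, since both ends are limits. For the compounds shown here, compound 3 remains the only one with a number, and the series now gathers at one limit: the limit of < 5000 nM in this assay, at which 3 of the 4 values shown sit.

As far as these compounds go, how far compound 1, compound 2 and compound 4 lie beyond that limit stays open. So does what an amine or a carboxylic acid on this phenyl ring would give.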